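Methoxy in place of hydroxy on the aromatic ring

The source may hold more compounds than are shown below. What is called first, only, known or untested is meant among the compounds shown, and "the series" means these compounds.

Three compounds share one core and differ only in the group on the aromatic ring. Compound 1 `O=C(CCCCCc1cccc(Br)c1)N1CCOC1=O` gives 430 nM in an assay on HEK293 cells for inhibition of N-acylethanolamine-hydrolyzing acid amidase (Rattus norvegicus), read by LC-MS, with a stated time of 30 min; a higher number here means a weaker inhibitor, a lower number a stronger inhibitor. Compound 2 `CSc1cccc(CCCCCC(=O)N2CCOC2=O)c1` gives 12800 nM, and compound 3 `O=C(CCCCCc1cccc(O)c1)N1CCOC1=O` gives 8640 nM. Compound 3 stands second highest of the three numbers; its nearest neighbour is compound 2, with a step of a 1.5-fold lower number from compound 2 to compound 3 (0.17 log units; within the scatter), while the step of a 20-fold higher number from compound 1 to compound 3 (1.30 log units; beyond the scatter) is large. The step of a 30-fold higher number from compound 1 to compound 2 (1.47 log units; beyond the scatter) is also large.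

Compound 4 `COc1cccc(CCCCCC(=O)N2CCOC2=O)c1` differs from compound 3 by methyl in place of hydrogen on an oxygen on an aromatic ring. Among the compounds with values here, no measured step concerns a methyl on an oxygen; the steps from compound 1 to compound 2 and from compound 1 to compound 3 show that the group at this position can move the number a long way, whereas the step from compound 2 to compound 3 shows two groups there giving numbers within the scatter of each other. Compound 4 is therefore expected to stay near compound 3, with a step of a 1.2-fold lower number from compound 3 to compound 4 (0.09 log units; within the scatter) in this assay. The estimate for compound 4 is 7000 nM, with a range from 1500 nM to 30000 nM.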

Compound 4, half-maximal inhibitory concentration: 16300 nM
The estimate for compound 4 lay 2.3-fold (0.37 log units) below the measured number, within the range that was stated.
By their numbers in this assay, from the lowest: compound 1; then compounds 3, 2 and 4 (each within the scatter of the next).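

Methyl in place of hydrogen on the oxygen gives a step within the scatter (a 1.9-fold higher number from compound 3 to compound 4 (0.28 log units; within the scatter)) in this assay, so hydroxy and methoxy cannot be told apart here. Methoxy and methylsulfanyl also lie within the scatter of each other (a 1.3-fold higher number from compound 2 to compound 4 (0.10 log units; within the scatter)), so all three steps among compound 2, compound 3 and compound 4 now stay within it and these three groups read as one cluster. Bromo alone stands apart, with a large step to methoxy (a 38-fold higher number from compound 1 to compound 4 (1.58 log units; beyond the scatter)) and large steps to the other two groups, which makes compound 1 the strongest inhibitor of the four.

From the compounds shown here alone, whether chloro, iodo, trifluoromethyl or an amine on this aromatic carbon would stand with bromo or with the other three groups remains open. Nothing measured here bears on why bromo parts from the other groups.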